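From chloro to isopropyl: what to expect of compound 4

This account rests on a few compounds, and the source may have more. Where it says the series, first, only, none or still open, it means among the compounds named here.

In an ADME assay on L6 cells (Rattus norvegicus) for cytotoxicity, read by resazurin assay, with a stated time of 72 h (on this read-out higher numbers stand for weaker inhibition and lower numbers for stronger inhibition), the measured compounds read as follows:
Compound 1 `OC(c1ccc(Cl)cc1)(c1ccc(C(F)(F)F)cc1)c1cncnc1` gives 66800 nM
Compound 2 `OC(c1ccc(Cl)cc1)(c1ccc(C(F)(F)F)cc1)c1cccnc1` gives 56400 nM
Compound 3 `CS(=O)(=O)Nc1ccc(C(O)(c2ccc(Cl)cc2)c2cccnc2)cc1` gives > 100000 nM (a limit of the assay)

Compound 2 gives 56400 nM here, a value that cannot be ranked against that of compound 1. Compound 3 gives > 100000 nM here, which is a limit of the assay and not a number. On these data alone, compound 4 `CC(C)c1ccc(C(O)(c2ccc(C(F)(F)F)cc2)c2cccnc2)cc1` differs from compound 2 in one place (isopropyl in place of chloro on an aromatic carbon)). Neither measured step changes that chloro, so both bear on this swap only loosely. Pyridin-3-yl in place of pyrimidin-5-yl gave a 1.2-fold lower number from compound 1 to compound 2 (0.07 log units; within the scatter) and methanesulfonamido in place of trifluoromethyl gave an at least 1.7-fold higher number from compound 2 to compound 3 (0.24 log units; that floor lies within the scatter) on the same scaffold of groups. On those two steps, no change beyond the scatter is expected in this assay for this swap, although isopropyl is untested so far. The estimated step is a 1.2-fold lower number from compound 2 to compound 4 (0.07 log units; within the scatter) in this comparison. Compound 4 is expected at 48000 nM in this assay. For compound 4 the estimated range runs from 20000 nM to 100000 nM on that basis.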

Compound 4, half-maximal inhibitory concentration: 56300 nM
Compound 4: middle estimate off by 1.2-fold (0.07 log units), on the low side, and the stated range covers the measured number.
By their numbers in this assay, from the lowest: compounds 4, 2 and 1 (each within the scatter of the next). At a limit, above all of these: compound 3.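

The earlier steps shown here changed the pyrimidin-5-yl and the trifluoromethyl, whereas here the position held by chloro is itself tested, and isopropyl in its place gives a 1.0-fold lower number from compound 2 to compound 4 (0.00 log units; within the scatter) in this assay. On this ring, then, a group of 3 heavy atoms, all carbon, can replace a single chlorine without moving the number beyond the scatter. Compound 3 remains the only compound at a limit, which is not a number: the limit of > 100000 nM in this assay, at which 1 of the 4 values shown sits.

The compounds shown leave open whether an amine, a carboxylic acid or a longer chain at this position would also stay within the scatter of compound 2. They also leave open whether isopropyl would give the same result on the core of compound 3, where methanesulfonamido stands in place of trifluoromethyl.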